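Swapping pyridin-4-yl for 1-benzothiophen-5-yl on a shared core

The source may hold more compounds than are shown below. What is called first, only, known or untested is meant among the compounds shown, and "the series" means these compounds.

In an ADME assay (liver) for metabolic stability, with Liver microsome (Rattus norvegicus) as the target, using microsomes and NADPH, with a stated time of 30 min, tested at 1 uM (a higher number here means faster removal of the compound, a lower number slower removal), compound 1 `Nc1ccc(S(=O)(=O)N2CCN(c3ncc(C(O)(C(F)(F)F)C(F)(F)F)cc3Br)CC2)cn1` gives 32 mL.min-1.g-1 and compound 2 `Nc1ccc(S(=O)(=O)N2CCN(c3ncc(C(O)(C(F)(F)F)C(F)(F)F)cc3-c3ccncc3)CC2)cn1` gives 31 mL.min-1.g-1, so compound 2 stands within the scatter of compound 1. Compound 3 `Nc1ccc(S(=O)(=O)N2CCN(c3ncc(C(O)(C(F)(F)F)C(F)(F)F)cc3-c3ccc4sccc4c3)CC2)cn1` has 1-benzothiophen-5-yl in place of pyridin-4-yl on an aromatic carbon. For the measured compounds named here, only one measured step bears on this place, the change from bromo to pyridin-4-yl, and a 1.0-fold lower number from compound 1 to compound 2 (0.01 log units; within the scatter) is small. One step is a thin guide, so only a slight upward move is expected for the larger group, a 1.4-fold higher number from compound 2 to compound 3 (0.13 log units; within the scatter), which stays within the scatter. The estimate for compound 3 is 42 mL.min-1.g-1, with an expected range of 18 mL.min-1.g-1 to 95 mL.min-1.g-1.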

Compound 3, intrinsic clearance in microsomes: 487 mL.min-1.g-1
For compound 3 the middle estimate is 12-fold (1.06 log units) below the measured one; measured number outside the range, above it.
By their numbers in this assay, from the lowest: compounds 2 and 1 (each within the scatter of the next); then compound 3.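

This position is not indifferent to what sits on it in this assay. Bromo and pyridin-4-yl gave no step beyond the scatter, yet 1-benzothiophen-5-yl brings a 16-fold higher number from compound 2 to compound 3 (1.20 log units; beyond the scatter) and, against bromo, a 15-fold higher number from compound 1 to compound 3 (1.18 log units; beyond the scatter), so the flat first step did not hold for every group here. No supporting information is available to explain this jump.

As far as these compounds go, whether the rise goes with the sulfur-containing ring or with the larger group as a whole stays open. A plain phenyl or a quinolinyl group at this place could fall near compound 2 or near compound 3.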